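The source may report more compounds than this note shows. Statements on the series, on what has been measured and on what is new or still open speak of the compounds shown alone.

Measured in a functional assay on A549 cells (Homo sapiens), read by MTT assay, with a stated time of 72 h; on this read-out lower numbers stand for stronger inhibition and higher numbers for weaker inhibition:
- Compound 1 `O=c1[nH]cnc2c1c(-c1ccccc1)cn2[C@@H]1O[C@H](CO)[C@@H](O)[C@H]1O`: > 100000 nM, a limit
- Compound 2 `O=c1[nH]cnc2c1c(-c1cc3ccccc3o1)cn2[C@@H]1O[C@H](CO)[C@@H](O)[C@H]1O`: > 20000 nM, a limit
- Compound 3 `Cc1nc(N)c2c(-c3ccco3)cn([C@@H]3O[C@H](CO)[C@@H](O)[C@H]3O)c2n1`: > 20000 nM, a limit

None of the three compounds gives a number in this assay. Compound 2 stands at the limit of > 20000 nM in this assay, at which 2 of the 3 values shown sit, so its position is known only as a limit.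

Compound 4 `Nc1nc2c(c(-c3cc4ccccc4o3)cn2[C@@H]2O[C@H](CO)[C@@H](O)[C@H]2O)c(=O)[nH]1` departs from compound 2 by one change: amino in place of hydrogen on an aromatic carbon. The amino stands between two ring nitrogen atoms.

Among the compounds with values here, the only measured step between two compounds differing in one place is a step that the two limits leave unreadable from compound 1 to compound 2. It concerns another substituent and gives no usable size. Compound 3 also carries an amino, but it differs from compound 2 in more than one place, and its value is likewise a limit. No size can therefore be carried over to this change, and no shift beyond the scatter is expected in this assay. The expected change, stated as an estimate, is a step that the limit leaves unreadable from compound 2 to compound 4. Another reading that is only a limit is likely.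

Compound 4 is estimated at 30000 nM, with an expected range from 8000 nM to 100000 nM.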

Compound 4, half-maximal inhibitory concentration: > 100000 nM
Compound 4 gave a limit, no number; the forecaster's own chance of this, stated with the estimate: 80%; middle value at least 3.3-fold (0.52 log units) away from the limit.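

In this assay, within the data shown here, compound 2 and compound 4 each give only a limit, so no step between them can be read. The compounds shown leave open whether amino in place of hydrogen on an aromatic carbon changes inhibition at all, and in which direction.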